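This account rests on a few compounds, and the source may have more. Where it says the series, first, only, none or still open, it means among the compounds named here.

In a physicochemical assay for permeability, using PAMPA (on this read-out higher numbers stand for higher permeability and lower numbers for lower permeability), compound 1 `O=C(O)CCn1c(=O)oc2cc(OCC3CC3)c(Cl)cc21` gives 19 nm/s. Compound 2 `CCOc1cc2oc(=O)n(CCC(=O)O)c2cc1Cl` gives < 10 nm/s, which is a limit of the assay and not a number. Its exact position is therefore unknown, and it can serve only as a rough starting point.

Compound 3 `C[C@@H](Oc1cc2oc(=O)n(CCC(=O)O)c2cc1Cl)c1ncccn1` keeps the core of compound 2 and adds one group: pyrimidin-2-yl in place of hydrogen on a saturated chain carbon bound to an oxygen on an aromatic ring and a saturated chain carbon. In words, this is pyrimidin-2-yl in place of hydrogen on a saturated chain carbon bound to an oxygen on an aromatic ring and a saturated chain carbon.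

Within the data shown here, one measured step touches a similar place. That step is an at least 1.9-fold lower number from compound 1 to compound 2 (0.27 log units; that floor lies within the scatter), with methyl in place of cyclopropyl on a saturated chain carbon bound to an oxygen on an aromatic ring. Its size is known only as a floor, and that floor lies within the scatter. Among the measured compounds shown here, no measured step adds a pyrimidin-2-yl group, so the guidance is weak.

In this assay, the estimated change is a step that the limit leaves unreadable from compound 2 to compound 3, so no step beyond the scatter is expected. The expected value for compound 3 is 9 nm/s, with an estimated range from 3 nm/s to 25 nm/s.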

Compound 3, apparent permeability: < 3 nm/s
Compound 3 ended at the assay's limit (the forecaster's own chance of this, stated with the estimate: 55%); middle value at least 3.0-fold (0.47 log units) away from the limit.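

In this assay compound 3 gives < 3 nm/s, which is a limit of the assay and not a number. Among these compounds, the one step that can be read for this position is an at least 6.3-fold lower number from compound 1 to compound 3 (0.80 log units; beyond the scatter); unlike the earlier exchange of cyclopropyl for methyl, whose floor stayed within the scatter, this exchange of the whole group on the oxygen, now bearing a pyrimidin-2-yl ring, goes beyond it. The step that adds pyrimidin-2-yl to compound 2 has a limit at both ends, so it cannot be read and gives the added ring no measured size of its own: the limit of < 3 nm/s in this assay, at which 1 of the 3 values shown sits.

Going by these compounds, how far the true value of compound 3 lies past its limit remains open, and so does the share of the lower number that belongs to the pyrimidin-2-yl ring rather than to the rest of the exchanged group. On these data alone, it is equally open whether a plain phenyl ring or a simple amine on the same saturated chain carbon would give a value that the assay can read as a number.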